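Bromine in Place of a Hydroxycyclohexylamino Group

The compounds below may be only part of what the source reports. "The series", "measured", "known", "first", "only" and "open" are said of these compounds alone.

Compound 1 `O=[N+]([O-])c1cccc(CNc2cc(C(F)(F)F)cc3[nH]ncc23)c1` in an assay for inhibition of Indoleamine 2,3-dioxygenase 1 (Homo sapiens), with stated times of 10 min and 60 min; on this read-out higher numbers stand for weaker inhibition and lower numbers for stronger inhibition: > 100000 nM, a limit of the assay.
Compound 2 `O=C(O)c1cccc(CNc2cc(C(F)(F)F)cc3[nH]ncc23)c1` in this assay: > 100000 nM, a limit of the assay.
Compound 3 `OC1CCCC(Nc2cccc(CNc3cc(C(F)(F)F)cc4[nH]ncc34)c2)C1` in this assay: > 100000 nM, a limit of the assay.

Compound 3 therefore has no number of its own, only the limit at which every value here sits, namely (the limit of > 100000 nM in this assay, at which 3 of the 3 values shown sit). The change to compound 4 `FC(F)(F)c1cc(NCc2cccc(Br)c2)c2cn[nH]c2c1` is bromo in place of (3-hydroxycyclohexyl)amino on an aromatic carbon. Two measured steps alter the same aromatic carbon, a step that the two limits leave unreadable from compound 1 to compound 3 and a step that the two limits leave unreadable from compound 2 to compound 3, but both run between limits, so neither gives a readable size or direction for this assay. No step beyond the scatter is expected, and the estimated step of a number no higher from compound 3 to compound 4 (the limit leaves the size open) reflects that. Compound 4 is expected near 100000 nM, within 20000 nM to 300000 nM, most likely reported again only as a limit.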

Compound 4, half-maximal inhibitory concentration: > 100000 nM
Compound 4: no number, only a limit; the forecaster's own chance of this, stated with the estimate: 70%; the middle value lies on the limit itself.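

Compound 4, like compound 1, compound 2 and compound 3, gives only a limit, so no new step can be read: the limit of > 100000 nM in this assay, at which 4 of the 4 values shown sit.

How strongly any of these compounds inhibits in this assay stays open, as does whether swapping the group on that aromatic carbon changes anything.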